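This account rests on a few compounds, and the source may have more. Where it says the series, first, only, none or still open, it means among the compounds named here.

Compound 3 `CC(C)=CCOc1cc(Nc2nccs2)ccc1C(C)C` is the starting point of this step. In a functional assay on MT2 cells (Homo sapiens) for cytotoxicity (on this read-out higher numbers stand for lower toxicity in this test and lower numbers for higher toxicity in this test), compound 3 gives 31000 nM, the highest of the two plain numbers in the set. Its nearest neighbour in value is compound 1 `CC(C)=CCOc1cc(Nc2ncccn2)ccc1Cl`, which in this assay gives 2500 nM. Compound 2 `CC(C)=CCOc1cc(Nc2nccc(C)n2)ccc1Cl` is reported in this assay only as a limit, < 200 nM, as noted in the limit of < 200 nM in this assay, at which 1 of the 3 values shown sits. Among the measured compounds shown here, the one measured step, an at least 12-fold lower number from compound 1 to compound 2 (1.09 log units; beyond the scatter), concerns a methyl in place of hydrogen on an aromatic carbon of the shared core and says nothing about the change now in question.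

Compound 4 `CC(C)=CCOc1cc(Nc2nccs2)ccc1Cl` differs from compound 3 by chloro in place of isopropyl on an aromatic carbon. For the measured compounds named here, no measured step covers this exchange; the only comparison at hand is that compound 1, which also carries a chloro group, sits well below compound 3 in this assay, though compound 1 and compound 4 also differ elsewhere.

On that basis a moderate drop, not a large one, is expected for compound 4 in this assay, amounting to a 3.9-fold lower number from compound 3 to compound 4 (0.59 log units; beyond the scatter). The estimate for compound 4 in this assay is therefore 8000 nM, within a range from 2000 nM to 30000 nM.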

Compound 4, half-maximal cytotoxic concentration: 26000 nM
The estimate for compound 4 lay 3.3-fold (0.51 log units) below the measured number; low and high end bracket the measured number.
By their numbers in this assay, from the lowest: compound 1; then compounds 4 and 3 (each within the scatter of the next). At a limit, below all of these: compound 2.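

In this assay, exchanging isopropyl for chloro on the aromatic carbon ortho to the (3-methylbut-2-en-1-yl)oxy group and para to the (1,3-thiazol-2-yl)amino group gives a 1.2-fold lower number from compound 3 to compound 4 (0.08 log units; within the scatter), so with that amino group in place, these two substituents are not told apart at this position. The larger difference instead follows the group on the nitrogen: with the chloro group common to both compounds, 1,3-thiazol-2-yl in place of pyrimidin-2-yl gives a 10-fold higher number from compound 1 to compound 4 (1.02 log units; beyond the scatter). The exchange of 4-methylpyrimidin-2-yl for 1,3-thiazol-2-yl on that nitrogen points the same way, an at least 130-fold higher number from compound 2 to compound 4 (2.11 log units; beyond the scatter), but the size of this step rests on a limit: the limit of < 200 nM in this assay, at which 1 of the 4 values shown sits.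

The compounds shown do not tell whether chloro and isopropyl would also match with pyrimidin-2-yl on the nitrogen, since the only direct pair carries 1,3-thiazol-2-yl. They also leave open how a methoxy group, an amine or a carboxylic acid would read at this position, and whether the 1,3-thiazol-2-yl result would hold with a longer chain in place of the (3-methylbut-2-en-1-yl)oxy group.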